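The source may hold more compounds than are shown below. What is called first, only, known or untested is meant among the compounds shown, and "the series" means these compounds.

Of the compounds shown here, two have been measured in a functional assay on HepG2 cells (Homo sapiens) for cytotoxicity, read by MTT assay, with a stated time of 72 h; a lower number here means a stronger inhibitor, a higher number a weaker inhibitor. Compound 1, with structure `Cc1cc(=O)n(-c2ccc(Br)cc2F)nc1C(=O)Nc1ccc(Oc2ncnc3sccc23)c(F)c1`, gives 13800 nM in this assay. Compound 2, with structure `O=C(Nc1ccc(Oc2ncnc3ccsc23)c(F)c1)c1nn(-c2ccc(F)cc2)ccc1=O`, gives 9160 nM in this assay, and the two numbers lie within the usual scatter of each other, so nothing separates them with confidence. Compound 3, with structure `Cc1ccc(-n2ccc(=O)c(C(=O)Nc3ccc(Oc4ncnc5ccsc45)c(F)c3)n2)cc1`, has not yet been measured in this assay. It differs from compound 2 in one place: methyl in place of fluoro on an aromatic carbon, which at the level of the whole group reads 4-fluorophenyl to 4-methylphenyl. Going by the values given here, no measured pair in this set shows what such a swap does, so the expectation rests only on the weak activity shared by compound 1 and compound 2. For compound 3 a step of a 1.0-fold higher number from compound 2 to compound 3 (0.02 log units; within the scatter) is expected, meaning no change beyond the scatter. Compound 3 is therefore estimated at 9500 nM, with a likely range from 3200 nM to 28000 nM.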

Compound 3, half-maximal inhibitory concentration: 24300 nM
The estimate for compound 3 lay 2.6-fold (0.41 log units) below the measured number; the measured number falls inside the stated range.
By their numbers in this assay, from the lowest: compounds 2, 1 and 3 (each within the scatter of the next, the first and the last beyond it).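

In this assay, putting methyl in place of fluoro on the aromatic carbon para to a large group gives a 2.7-fold higher number from compound 2 to compound 3 (0.42 log units; beyond the scatter) and so counts as a modest loss of inhibition. This shows that the position is not indifferent to what sits on it: exchanging one heavy atom for another, with no ring, hydrogen-bond donor, hydrogen-bond acceptor or net charge added, is enough to move the number beyond the scatter. Nothing available here explains why the methyl compound gives the higher number.

With only fluoro and methyl compared at this position, one step cannot show a trend across groups. Plain hydrogen, chloro, methoxy or a longer chain such as ethyl there would show whether the number keeps rising with other groups or whether this step stands alone.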